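Aryl exchange from compound 1 to compound 4

This account rests on a few compounds, and the source may have more. Where it says the series, first, only, none or still open, it means among the compounds named here.

In a physicochemical assay for permeability, using PAMPA (a lower number here means that the compound crosses the layer more slowly, a higher number that the compound crosses the layer faster), compound 1 `Cc1oc(-c2ccc(Cl)cc2)nc1CN1CCC(C(=O)NCCCN2C[C@H](C)C[C@H](C)C2)CC1` reads > 635 10^-6 cm/s, which is a limit of the assay and not a number. Compound 4 `Cc1cccc(F)c1-c1nc(CN2CCC(C(=O)NCCCN3C[C@H](C)C[C@H](C)C3)CC2)c(C)o1` differs from it at one place, on an aromatic carbon: 2-fluoro-6-methylphenyl in place of 4-chlorophenyl on an aromatic carbon. Compound 2 `Cc1ccccc1-c1nc(CN2CCC(C(=O)NCCCN3[C@H](C)CCC[C@@H]3C)CC2)c(C)o1` gives 55.4 10^-6 cm/s and compound 3 `CCCN(CCC)CCNC(=O)C1CCN(Cc2nc(-c3ccccc3C)oc2C)CC1` gives 913 10^-6 cm/s. For the measured compounds named here, the only measured step, a 16-fold higher number from compound 2 to compound 3 (1.22 log units; beyond the scatter), is large, but it puts dipropylamino in place of (2,6-dimethylpiperidin-1-yl)methyl and leaves the aromatic group untouched. Going by the values given here, no measured step covers the present exchange, so that size is not carried over. In this assay the expected step is an at least 1.0-fold lower number from compound 1 to compound 4 (0.02 log units; that floor lies within the scatter), with no change beyond the scatter expected in either direction. For compound 4 the estimated value is 600 10^-6 cm/s, with an expected range of 150 10^-6 cm/s to 1500 10^-6 cm/s.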

Compound 4, apparent permeability: 234 10^-6 cm/s
Estimate against measurement, compound 4: 2.6-fold (0.41 log units) above; low and high end bracket the measured number.
By their numbers in this assay, from the lowest: compound 2; then compound 4; then compound 3.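

In this assay, the exchange at this aromatic carbon of the shared core gives an at least 2.7-fold lower number from compound 1 to compound 4 (0.43 log units; beyond the scatter) and so counts as a real change, not scatter. Swapping 4-chlorophenyl for 2-fluoro-6-methylphenyl is the first measured change to the aromatic group with the amine side of the molecule held constant. Only a floor can be given for the step, since the reading for compound 1 is a limit of the assay and not a number: the limit of > 635 10^-6 cm/s in this assay, at which 1 of the 4 values shown sits.

From the compounds shown here alone, the full size of the step remains open, as does how the fluorine and the methyl each contribute. A plain phenyl or a pyridin-3-yl group at this position, on the same core, would help separate those contributions.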